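Extending the alkoxy chain on the shared benzylamide core

The compounds below may be only part of what the source reports. "The series", "measured", "known", "first", "only" and "open" are said of these compounds alone.

Measured compounds:
compound 1 `CC(C(=O)NCc1ccc(C(C)(C)C)cc1N1CCCC1)c1ccc(NS(C)(=O)=O)c(F)c1` gives 8.1 nM
compound 2 `CC(C(=O)NCc1ccc(C(C)(C)C)cc1N1CCCCC1)c1ccc(NS(C)(=O)=O)c(F)c1` gives 1.9 nM
compound 3 `CCCOc1cc(C(C)(C)C)ccc1CNC(=O)C(C)c1ccc(NS(C)(=O)=O)c(F)c1` gives 4.4 nM

In an assay on cells for antagonist activity at transient receptor potential cation channel subfamily V member 1 (Homo sapiens), read by FLIPR and calcium flux, with a stated time of 6 min (on this read-out higher numbers stand for weaker inhibition and lower numbers for stronger inhibition), compound 3 stands second highest of the three numbers. Its nearest neighbour is compound 1, and the gap a 1.8-fold lower number from compound 1 to compound 3 (0.27 log units; within the scatter) lies within the scatter, so the two cannot be ordered. Its furthest neighbour is compound 2, with a 2.3-fold higher number from compound 2 to compound 3 (0.36 log units; beyond the scatter), a modest separation that does exceed the scatter.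

Compound 4 `CC(C(=O)NCc1ccc(C(C)(C)C)cc1OCC(C)(C)C)c1ccc(NS(C)(=O)=O)c(F)c1` is the untested member. It differs from compound 3 by tert-butyl in place of ethyl on a saturated chain carbon bound to an oxygen on an aromatic ring. Among the compounds with values here, none of the measured steps alters the chain on the aromatic oxygen; the steps that exist replace a ring amine with propoxy, a 1.8-fold lower number from compound 1 to compound 3 (0.27 log units; within the scatter) and a 2.3-fold higher number from compound 2 to compound 3 (0.36 log units; beyond the scatter), and all three variants at this position fall within a narrow band. Within the data shown here, with no direct precedent, the account expects compound 4 to move by about a 1.1-fold lower number from compound 3 to compound 4 (0.04 log units; within the scatter), that is, no step clearly beyond the scatter. Compound 4 is therefore estimated at 4 nM, with a range from 1.5 nM to 12 nM.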

Compound 4, inhibition constant: 3.8 nM
For compound 4 the middle estimate is 1.1-fold (0.02 log units) above the measured one, and the stated range covers the measured number.
By their numbers in this assay, from the lowest: compounds 2, 4, 3 and 1 (each within the scatter of the next, the first and the last beyond it).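

Swapping ethyl for tert-butyl on the saturated chain carbon bound to the oxygen is the first change within the alkoxy chain itself, and in this assay it gives a 1.2-fold lower number from compound 3 to compound 4 (0.06 log units; within the scatter), so this larger, branched chain end leaves the number unresolved from that of the propoxy compound. Against the ring amines, neopentyloxy gives a 2.0-fold higher number from compound 2 to compound 4 (0.30 log units; within the scatter) and a 2.1-fold lower number from compound 1 to compound 4 (0.33 log units; beyond the scatter), a pattern that differs from the one seen for propoxy, although compound 3 and compound 4 themselves cannot be told apart. Nothing at hand explains why the chain end can change this way without a clear shift in the number.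

The compounds shown leave open whether a longer straight chain, a cyclohexylmethyl group or a terminal amine on the oxygen would stay within this range. A carboxylic acid at the chain end also remains an open case.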